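The source may hold more compounds than are shown below. What is called first, only, known or untested is meant among the compounds shown, and "the series" means these compounds.

Measured compounds:
compound 1 `CC(C)=CCCN(C)C1CCN(CCCc2c[nH]c3ccc(-n4cnnc4)cc23)CC1` with 24 nM
compound 2 `c1ccc2c(c1)CCC2NC1CCN(CCCc2c[nH]c3ccc(-n4cnnc4)cc23)CC1` with 280 nM

Among the compounds with values here, in an assay on CHO cells for displacement of a labelled ligand from 5-hydroxytryptamine receptor 1B (Homo sapiens) (on this read-out higher numbers stand for weaker inhibition and lower numbers for stronger inhibition), compound 1 gives 24 nM, and compound 2 gives 280 nM, the higher of the two numbers; the only measured step, a 12-fold higher number from compound 1 to compound 2 (1.07 log units; beyond the scatter), separates them. Compound 3 `CC(=O)Nc1ccc(CNC2CCN(CCCc3c[nH]c4ccc(-n5cnnc5)cc34)CC2)cc1` is not yet measured in this assay. It differs from compound 2 in 4-acetamidobenzyl in place of 2,3-dihydro-1H-inden-1-yl on an amine nitrogen. Within the data shown here, no measured step shares this exact change; the step from compound 1 to compound 2 only shows that exchanging the group at this end of the molecule can move the number strongly in either direction, so a step in this assay of uncertain direction, and probably smaller than that one, is expected. Compound 3 is therefore expected to give about 150 nM, within the range 30 nM to 800 nM, which amounts to an expected step of a 1.9-fold lower number from compound 2 to compound 3 (0.27 log units; within the scatter).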

Compound 3, half-maximal inhibitory concentration: 45 nM
The estimate for compound 3 lay 3.3-fold (0.52 log units) above the measured number; measured number inside the range.
By their numbers in this assay, from the lowest: compounds 1 and 3 (each within the scatter of the next); then compound 2.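

In this assay, the position on the amine nitrogen proves able to recover from the weak number of compound 2: the change to 4-acetamidobenzyl gives a 6.2-fold lower number from compound 2 to compound 3 (0.79 log units; beyond the scatter), and compound 3 at 45 nM stands within the scatter of compound 1 at 24 nM. A ring-bearing group on this nitrogen, with the amine hydrogen kept, is therefore compatible with a number as low as that of the open-chain tertiary amine. No measurement is available that would explain the step.

The change removes the five-membered ring and adds the acetamido group together, so the compounds shown do not separate the two. A plain benzyl group on this nitrogen would do so, and a methyl group added to the amine nitrogen of compound 3 would test whether the amine hydrogen matters.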